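Stereochemical variation in a polyhydroxylated piperidine acid series

The source may report more compounds than this note shows. Statements on the series, on what has been measured and on what is new or still open speak of the compounds shown alone.

The three measured compounds share one set of atoms and bonds and differ only in how their ring stereocentres are drawn. In an assay on isolated protein for inhibition of cytosolic endo-beta-N-acetylglucosaminidase (Homo sapiens), tested at 1000 uM (on this read-out lower numbers stand for less inhibition and higher numbers for more inhibition at the one concentration tested (going by the name of the read-out)), compound 1 `O=C(O)[C@H]1NC[C@H](O)[C@@H](O)[C@@H]1O` gives 43%, compound 2 `O=C(O)[C@@H]1NC[C@@H](O)[C@@H](O)[C@H]1O` gives 26%, and compound 3 `O=C(O)[C@@H]1NC[C@@H](O)[C@@H](O)[C@@H]1O` gives 2.1%, the lowest of the three numbers.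

Compound 4 `O=C(O)[C@@H]1NC[C@H](O)[C@H](O)[C@H]1O` has not yet been measured. It differs from compound 3 only in configuration: the two compounds have the same atoms and bonds and differ only in configuration as drawn: 3 of 4 stereo elements differ; a stereocentre at a saturated ring carbon is drawn R in compound 3 and S in compound 4; a stereocentre at a saturated ring carbon is drawn R in compound 3 and S in compound 4; a stereocentre at a saturated ring carbon is drawn R in compound 3 and S in compound 4.

Every measured step in this set is also a pure change of configuration. The step of a number 17 percentage points lower from compound 1 to compound 2 (beyond the scatter) changes three of four stereo elements, the step of a number 40.9 percentage points lower from compound 1 to compound 3 (beyond the scatter) changes two, and the step of a number 23.9 percentage points lower from compound 2 to compound 3 (beyond the scatter) changes only one. Each of these steps moved the inhibition beyond the scatter, and the three inversions here are of the same kind as those between compounds 1 and 2 (the fact that compounds 1 and 2 differ only in the configuration as drawn). Because compound 3 already sits near the bottom of the scale at 2.1%, a change of the size seen so far can only raise the number. Compound 4 is therefore expected to inhibit more strongly than compound 3, with an estimated step of a number 22.9 percentage points higher from compound 3 to compound 4 (beyond the scatter). For compound 4 the estimate in this assay is 25%, within a range from 2% to 50%.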

Compound 4, a percentage reported as inhibition, at one concentration (the size of the read-out at that concentration, not a potency): 39%
Beside the measured number, compound 4's estimate is 14 percentage points below it, and the stated range covers the measured number.
By their numbers in this assay, from the lowest: compound 3; then compound 2; then compounds 4 and 1 (each within the scatter of the next).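

In this assay, the step of a number 36.9 percentage points higher from compound 3 to compound 4 (beyond the scatter) shows that three inversions together can do far more than restore a modest level of inhibition, so the low number of compound 3 belongs to its particular arrangement and not to the shared atoms and bonds. The number of changed stereo elements does not set the size of a step in this set: the step of a number 13 percentage points higher from compound 2 to compound 4 (beyond the scatter) changes two of them and lies beyond the scatter, whereas the step of a number 4 percentage points lower from compound 1 to compound 4 (within the scatter) changes three and does not. Configuration is the only thing that separates compound 3 from compound 4: the fact that compounds 3 and 4 differ only in the configuration as drawn

Since the three inversions in compound 4 came together, the share of each stereocentre in the step cannot be separated, and all these numbers come from one concentration, so they give no potency. The compounds shown also leave open whether the inhibition of compound 1 or compound 4 would survive replacing the carboxylic acid with a methyl ester or a hydroxymethyl group.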